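Swapping a ring on the amide-type nitrogen of compound 2

This account rests on a few compounds, and the source may have more. Where it says the series, first, only, none or still open, it means among the compounds named here.

Compound 1 `COc1ccc(-c2cnc(NC(=O)CCCCCCNC(=O)C(O)(O)C(F)(F)F)s2)cc1`: 930 nM
Compound 2 `O=C(CCCCCCNC(=O)C(O)(O)C(F)(F)F)Nc1nc2ccccc2o1`: 3450 nM
Compound 3 `COc1cc(NC(=O)CCCCCCNC(=O)C(O)(O)C(F)(F)F)cc(OC)c1OC`: 14100 nM

These three values come from a functional assay on HCT-116 cells (Homo sapiens) for inhibition, read by colorimetric assay, with a stated time of 3 days; on this read-out higher numbers stand for weaker inhibition and lower numbers for stronger inhibition. Compound 2, at 3450 nM, holds the middle place among them. Its number lies beyond the usual scatter from both of the others: compound 1 gives the lower 930 nM, and compound 3 gives the higher 14100 nM.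

The next compound to be tested is compound 4 `O=C(CCCCCCNC(=O)C(O)(O)C(F)(F)F)Nc1c(F)cc(F)cc1F`. The change from compound 2 is this: 2,4,6-trifluorophenyl in place of 1,3-benzoxazol-2-yl on an amide-type nitrogen. In words, 2,4,6-trifluorophenyl stands in place of 1,3-benzoxazol-2-yl on an amide-type nitrogen.

Among the measured compounds shown here, no two measured compounds differ in only one place, so the data offer no direct guide to this swap. Compound 3 also has a six-membered aromatic ring of carbon only on that nitrogen, and its value of 14100 nM leaves room for a weaker result. With so little to go on, the expected change in this assay is none beyond the scatter, and the estimated step is a 1.2-fold higher number from compound 2 to compound 4 (0.06 log units; within the scatter). For compound 4 the estimated value is 4000 nM, with an expected range from 1000 nM to 14000 nM.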

Compound 4, half-maximal inhibitory concentration: 22200 nM
Estimate against measurement, compound 4: 5.6-fold (0.74 log units) below; measured number outside the range, above it.
By their numbers in this assay, from the lowest: compound 1; then compound 2; then compounds 3 and 4 (each within the scatter of the next).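

In this assay, placing 2,4,6-trifluorophenyl on the amide-type nitrogen in place of 1,3-benzoxazol-2-yl gives a 6.4-fold higher number from compound 2 to compound 4 (0.81 log units; beyond the scatter) and so a clear loss of inhibition, which shows that this position responds to the group it carries. The two groups have the same count of heavy atoms, so that count alone does not settle the outcome; the entering group has one ring instead of two and no hydrogen-bond acceptors instead of two. Nothing measured here explains the rise.

The compounds shown leave open how much of this step goes with the fluorine atoms and how much with the loss of the second ring, a question that a plain phenyl on the same nitrogen would address. Also open, from the compounds shown here alone, is how a phenyl ring carrying an amine or a carboxylic acid would behave there.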